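Indolyl for furanyl in a biaryl amide acid series

This account rests on a few compounds, and the source may have more. Where it says the series, first, only, none or still open, it means among the compounds named here.

Measured so far:
- compound 1 `CC(C)N(Cc1cccc(OCCCCCC(=O)O)c1)C(=O)c1ccc(-c2cccc3ccccc23)cc1`; in an ADME assay on HEK293 cells (Homo sapiens) for cytotoxicity, read by CellTiter-Glo and resazurin assay, with a stated time of 72 h (on this read-out higher numbers stand for an effect only at larger amounts of compound and lower numbers for an effect already at smaller amounts), compound 1 gives only a limit, > 26000 nM.
- compound 2 `CC(C)COc1cccc(-c2ccc(C(=O)N(Cc3cccc(OCCCCCC(=O)O)c3)C(C)C)cc2)c1`; in this assay compound 2 gives only a limit, > 26000 nM.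
- compound 3 `CC(C)N(Cc1cccc(OCCCCCC(=O)O)c1)C(=O)c1ccc(-c2ccco2)cc1`; in this assay compound 3 gives only a limit, > 26000 nM.

Compound 3 thus stands at the limit of this assay together with both other compounds, as the limit of > 26000 nM in this assay, at which 3 of the 3 values shown sit, shows. Among the measured compounds shown here, none of the measured steps can be read: a step that the two limits leave unreadable from compound 1 to compound 3, a step that the two limits leave unreadable from compound 2 to compound 3 and a step that the two limits leave unreadable from compound 1 to compound 2 all run between two limits, so no size and no direction is known for any change at this position of the core.

Compound 4 `CC(C)N(Cc1cccc(OCCCCCC(=O)O)c1)C(=O)c1ccc(-c2ccc3[nH]ccc3c2)cc1` carries the change (1H-indol-5-yl in place of furan-2-yl on an aromatic carbon). The measured steps bearing on this position give no readable size, so no step beyond the scatter can be expected in this assay, and the value is most likely to be a limit again. Compound 4 is therefore estimated at 30000 nM, with a range from 12000 nM to 80000 nM. The expected step is a step that the limit leaves unreadable from compound 3 to compound 4.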

Compound 4, half-maximal effective concentration: > 26000 nM
Compound 4: no number, only a limit; the forecaster's own chance of this, stated with the estimate: 75%; the middle value does not contradict the limit.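

Compound 4 also gives only a limit in this assay and the steps to it from compound 1, compound 2 and compound 3 cannot be read: the limit of > 26000 nM in this assay, at which 4 of the 4 values shown sit.

The compounds shown leave open whether any group at this position of the shared core gives a measurable effect in this assay and how large any step there would be.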